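Secondary amide variant of a sulfonyl piperidine carboxamide

This account rests on a few compounds, and the source may have more. Where it says the series, first, only, none or still open, it means among the compounds named here.

Compound 2 `CCN(CC)S(=O)(=O)c1ccc(S(=O)(=O)N2CCC[C@@H](C(=O)N3CCC(C(F)(F)F)CC3)C2)cc1` gives 320 nM in a functional assay on MIA PaCa-2 cells (Homo sapiens) for inhibition, read by MTT assay, with a stated time of 7 days (on this read-out higher numbers stand for weaker inhibition and lower numbers for stronger inhibition), the highest of the three numbers recorded. Compound 1 `CCN(CC)C(=O)c1ccc(S(=O)(=O)N2CCC[C@@H](C(=O)N3CCC(F)(F)CC3)C2)cc1` gives 70 nM, and compound 3 `O=C([C@@H]1CCCN(S(=O)(=O)c2ccc(S(=O)(=O)C3COC3)cc2)C1)N1CCC(F)(F)CC1` gives 110 nM. Going by the values given here, the only single-point step among them, a 1.6-fold higher number from compound 1 to compound 3 (0.20 log units; within the scatter), concerns the aromatic substituent and does not bear on the amide. Compound 4 `CCN(CC)S(=O)(=O)c1ccc(S(=O)(=O)N2CCC[C@@H](C(=O)NC3CCOCC3)C2)cc1` differs from compound 2 by (oxan-4-yl)amino in place of 4-(trifluoromethyl)piperidin-1-yl on a carbonyl carbon. Among the compounds with values here, no measured step alters this carbonyl substituent, so the data give no direction for the change. The author therefore expects for compound 4 a step of a 1.6-fold higher number from compound 2 to compound 4 (0.19 log units; within the scatter) in this assay that does not clearly exceed the scatter, with wide uncertainty. Compound 4 is estimated at 500 nM, between 150 nM and 2000 nM.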

Compound 4, half-maximal inhibitory concentration: 3770 nM
For compound 4 the middle estimate is 7.5-fold (0.88 log units) below the measured one; measured number outside the range, above it.
By their numbers in this assay, from the lowest: compounds 1 and 3 (each within the scatter of the next); then compound 2; then compound 4.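

At this carbonyl carbon the substituent matters in this assay: (oxan-4-yl)amino in place of 4-(trifluoromethyl)piperidin-1-yl gives a 12-fold higher number from compound 2 to compound 4 (1.07 log units; beyond the scatter), so inhibition is much weaker with the secondary amide. Going by these compounds alone, this is the first measured change at this place, and it shows that the position is not tolerant of every amide. Nothing on hand accounts for the loss. The step changes the ring and adds the amide hydrogen together, so the compounds shown leave open which of these counts; a morpholine amide or a cyclohexylamino group here would help separate them.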